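The source may hold more compounds than are shown below. What is called first, only, known or untested is meant among the compounds shown, and "the series" means these compounds.

The measured compounds so far:

Compound 1, `CC1=CCC2C(CC[C@@]2(C)O)C(C)(C)C1CC[C@@H]1[C@@]2(C)CCC(=O)C(C)(C)O[C@@H]2CC[C@]1(C)O`, gives > 50000 nM in a functional assay on MCF7 cells (Homo sapiens) for antiproliferative activity, read by MTT assay, with a stated time of 72 h; a lower number here means a stronger inhibitor, a higher number a weaker inhibitor; this value is a limit of the assay, not a number.
Compound 2, `CC1=CC[C@H]2[C@H](CC[C@]2(C)O)C(C)(C)[C@@H]1CC[C@H]1[C@]2(C)CC[C@H](OC(=O)NCc3ccccc3)C(C)(C)O[C@H]2CC[C@@]1(C)O`, gives 24500 nM in this assay.

Compound 2 therefore stands as the only compound in this set with an actual number; the other value recorded is only a limit, as shown by the limit of > 50000 nM in this assay, at which 1 of the 2 values shown sits. Compound 3, `CC1=CC[C@H]2[C@H](CC[C@]2(C)O)C(C)(C)[C@@H]1CC[C@H]1[C@]2(C)CC[C@H](OC(=O)c3ccc([N+](=O)[O-])o3)C(C)(C)O[C@H]2CC[C@@]1(C)O`, has not yet been tested. It shares its core with compound 2 and differs from it in a single place: 5-nitrofuran-2-yl in place of benzylamino on a carbonyl carbon. Among the compounds with values here, since no step between two measured compounds exists here, the size of this change cannot be read off from the data, and any expectation rests on compound 2 alone, with 24500 nM as the only anchor. The step of a 2.0-fold lower number from compound 2 to compound 3 (0.31 log units; beyond the scatter) is expected to be a modest gain in potency, not much beyond the usual scatter. Compound 3 is estimated at 12000 nM, with a range from 3000 nM to 40000 nM.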

Compound 3, half-maximal inhibitory concentration: 21300 nM
Compound 3: middle estimate off by 1.8-fold (0.25 log units), on the low side, and the stated range covers the measured number.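

In this assay, the exchange of benzylamino for 5-nitrofuran-2-yl on a carbonyl carbon gives a 1.2-fold lower number from compound 2 to compound 3 (0.06 log units; within the scatter), so this position accepts two quite different groups with no readable difference between their numbers. The exchange replaces a six-membered aromatic ring of carbon only with a five-membered aromatic ring holding one hetero atom, and it removes the hydrogen-bond donor of benzylamino while bringing in 3 hydrogen-bond acceptors, yet compound 2 and compound 3 cannot be told apart here, so in this pair neither that donor nor the six-membered ring is needed to keep the reading. Compound 1 remains a limit of the assay and not a number, so no step involving it can be read: the limit of > 50000 nM in this assay, at which 1 of the 3 values shown sits.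

On these data alone, it remains open whether the nitro group or the furan ring counts for anything on its own, a question that furan-2-yl without the nitro group would address. As far as these compounds go, it is equally open whether a quite different group on this carbonyl carbon, such as a plain methyl, a longer alkyl chain or a primary amine, would move the number beyond the scatter in either direction.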